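The source may hold more compounds than are shown below. What is called first, only, known or untested is meant among the compounds shown, and "the series" means these compounds.

Compound 1, `N#Cc1ccc(OCc2nnc(-c3ccccc3)o2)cc1F`, is essentially inactive in a functional assay on MCF7 cells (Homo sapiens) for cytotoxicity, read by MTT assay, with a stated time of 48 h (a higher number here means a weaker inhibitor, a lower number a stronger inhibitor), where compound 1 only reaches the limit of the measurement, > 50000 nM. Compound 2, `COc1ccc(-c2nnc(COc3ccc(C#N)c(F)c3)o2)cc1`, carries one change, (methoxy in place of hydrogen on an aromatic carbon), and in this assay compound 2 gives 42200 nM. That change made an at least 1.1-fold lower number from compound 1 to compound 2 (0.07 log units; that floor lies within the scatter), so the two compounds cannot be told apart on this reading. Compound 3, `c1ccc(-c2nnc(COc3ccc(-c4nnco4)cc3)o2)cc1`, has a different core; how its core differs from that of compound 1 is not broken down here. In this assay compound 3 also reaches only the limit of the measurement, > 50000 nM. Compound 4, `COc1ccc(-c2nnc(COc3ccc(-c4nnco4)cc3)o2)cc1`, has not yet been measured and differs from compound 3 by methoxy in place of hydrogen on an aromatic carbon, the same change, at the same kind of place, that separates compound 1 from compound 2. Because the limit of > 50000 nM in this assay, at which 2 of the 3 values shown sit, already marks two of the three values, the step from compound 3 to compound 4 is expected to be small, about a step that the limit leaves unreadable from compound 3 to compound 4. Compound 4 is therefore estimated at 60000 nM, most likely again only a limit, somewhere between 30000 nM and 150000 nM.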

Compound 4, half-maximal inhibitory concentration: 31200 nM
Beside the measured number, compound 4's estimate is 1.9-fold (0.28 log units) above it; the range from low to high includes it.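

In this assay, the change from phenyl to 4-methoxyphenyl gives an at least 1.6-fold lower number from compound 3 to compound 4 (0.20 log units; that floor lies within the scatter), so this pair alone does not establish a real gain in potency. Set beside the earlier pair, the change lowers the number on both cores, but neither step is shown to exceed the usual scatter, and the two sizes cannot be compared: the same change on two cores in this assay, an at least 1.1-fold lower number (0.07 log units; that floor lies within the scatter) from compound 1 to compound 2 and an at least 1.6-fold lower number (0.20 log units; that floor lies within the scatter) from compound 3 to compound 4; the limit leaves it open whether they differ The result is therefore a direction that fits both pairs, not a transferable effect of known size, and the true values of the two compounds without methoxy remain hidden: the limit of > 50000 nM in this assay, at which 2 of the 4 values shown sit.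

The compounds shown leave open whether a different group in the same place, such as an amine, a carboxylic acid or a longer alkoxy chain, would shift the number clearly. They also leave open how large the methoxy step would be on a core whose compound without methoxy gives a real number rather than a limit.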